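Adding a Methoxy Group to an Inactive Core

The source may report more compounds than this note shows. Statements on the series, on what has been measured and on what is new or still open speak of the compounds shown alone.

Compound 1 `O=C1CNc2nc(Nc3ccccc3)ncc2N1` was examined in a functional assay on MDA-MB-468 cells (Homo sapiens) for cytotoxicity, read by MTT assay, with a stated time of 48 h; a higher number here means a weaker inhibitor, a lower number a stronger inhibitor. In this assay compound 1 gives > 100000 nM, which is a limit of the assay rather than a number. Compound 2 `COc1ccc(Nc2ncc3c(n2)NCC(=O)N3)cc1` carries methoxy in place of hydrogen on an aromatic carbon. In this assay compound 2 gives > 100000 nM, again a limit. The step from compound 1 to compound 2 is accordingly a step that the two limits leave unreadable from compound 1 to compound 2. Compound 3 `CN1CC(=O)Nc2cnc(Nc3ccccc3)nc21` differs from compound 1 by methyl in place of hydrogen on a nitrogen on an aromatic ring in a ring. In this assay compound 3 gives > 100000 nM, also a limit. The step from compound 1 to compound 3 is a step that the two limits leave unreadable from compound 1 to compound 3. All three results share (the limit of > 100000 nM in this assay, at which 3 of the 3 values shown sit).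

Compound 4 `COc1cccc(Nc2ncc3c(n2)N(C)CC(=O)N3)c1` has not yet been measured and differs from compound 3 by methoxy in place of hydrogen on an aromatic carbon. This is the same kind of change as from compound 1 to compound 2, though there the methoxy sits para to a large group, while in compound 4 it sits meta to a large group. The step from compound 3 to compound 4 is expected to be a number no higher from compound 3 to compound 4 (the limit leaves the size open), resting on the limit of > 100000 nM in this assay, at which 3 of the 3 values shown sit, at which compound 1 and compound 2 both sit. Compound 4 is therefore expected to give about 100000 nM, between 50000 nM and 200000 nM, most probably reported only as a limit once more.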

Compound 4, half-maximal inhibitory concentration: > 100000 nM
Compound 4: no number, only a limit; the forecaster's own chance of this, stated with the estimate: 85%; the middle value lies on the limit itself.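

In this assay compound 4 gives > 100000 nM, again a limit of the assay and not a number. Among these compounds, the change from compound 3 to compound 4 therefore yields no step of readable size. The compounds shown leave open how strong any of them is in this assay, and whether a methoxy or methyl group alters that strength at all.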